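Swapping the amide substituent in a series of level readings

This account rests on a few compounds, and the source may have more. Where it says the series, first, only, none or still open, it means among the compounds named here.

Compound 1 `Cc1cccc(Oc2ccnc(N3CCC[C@H]3C(=O)NCc3cccnc3)n2)c1`, in an assay on isolated protein for inhibition of Ephrin type-B receptor 4 (Homo sapiens), read by HTRF, tested at 10 uM; a lower number here means less inhibition, a higher number more inhibition at the concentration tested (going by the name of the read-out): 0%
Compound 2 `COC[C@@H]1CCCN1C(=O)C1CCCN1c1cc(Nc2cccc(Br)c2)ncn1`, in this assay: 0%
Compound 3 `Cc1cccc(Oc2ccnc(N3CCC[C@H]3C(=O)NCCCn3ccnc3)n2)c1`, in this assay: 0%

Compound 3 stands level with compounds 1 and 2 on these numbers; its nearest neighbour in structure is compound 1, and the step of no change at the digits printed from compound 1 to compound 3 (within the scatter) lies within the scatter. Compound 4 `COC(=O)C(CO)NC(=O)[C@@H]1CCCN1c1nccc(Oc2cccc(C)c2)n1` differs from compound 3 by 2-hydroxy-1-(methoxycarbonyl)ethyl in place of 3-(1H-imidazol-1-yl)propyl on an amide-type nitrogen. Going by the values given here, the only measured step that bears on this change is no change at the digits printed from compound 1 to compound 3 (within the scatter), which also exchanged the group on the amide-type nitrogen and showed nothing beyond the scatter. Among the compounds with values here, that step started from a compound showing no inhibition, so it cannot reveal whether another group might raise inhibition, and no measured pair contains the entering group. The expectation is therefore a step of no change at the digits printed from compound 3 to compound 4 (within the scatter) in this assay, none beyond the scatter. Compound 4 is expected to give 0% in this assay, estimated to lie between -8% and 15%.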

Compound 4, a percentage reported as inhibition, at one concentration (the size of the read-out at that concentration, not a potency): 0%
Beside the measured number, compound 4's estimate shows no gap at the digits printed; measured number inside the range.
By their numbers in this assay, from the lowest: compounds 1, 2, 3 and 4 (each within the scatter of the next).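

On the amide-type nitrogen of this series, a group with no ring, 2-hydroxy-1-(methoxycarbonyl)ethyl, now stands alongside the two ring-bearing groups, and in this assay the reading stays put (no change at the digits printed from compound 3 to compound 4 (within the scatter)) and (no change at the digits printed from compound 1 to compound 4 (within the scatter)). Three quite different groups at this one place therefore give the same reading, so neither removing the aromatic ring nor bringing in a hydroxyl and a methyl ester produces measurable inhibition at the concentration tested. Since every reading sits at zero, these steps show no way of raising inhibition, and no measurement on hand accounts for them.

Going by these compounds, whether a free carboxylic acid, a primary amine or a longer alkyl chain at this nitrogen would give any inhibition remains open. So does whether any group here could do so on the core of compound 4.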